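Replacing dimethylamino with methoxy in compound 2

A few compounds are considered here, and "the series" means these few. Any claim that something is new, unique, unknown or untested is made for them only; others in the source may bear on it.

In a functional assay on B16-F0 cells (Mus musculus) for inhibition, read by CCK-8 assay, with a stated time of 48 h (on this read-out higher numbers stand for weaker inhibition and lower numbers for stronger inhibition), compound 1 `COc1cc(-c2ccnc3cc(-c4ccccc4)nn23)cc(OC)c1OC` gives 4730 nM. Among the measured compounds shown here, compound 2 `COc1cc(-c2ccnc3cc(-c4ccc(N(C)C)cc4)nn23)cc(OC)c1OC` gives 702 nM, the lower of the two numbers so far. The next structure, compound 3 `COc1ccc(-c2cc3nccc(-c4cc(OC)c(OC)c(OC)c4)n3n2)cc1`, keeps the shared core and changes one group: methoxy in place of dimethylamino on an aromatic carbon. For the measured compounds named here, only one measured step bears on this change: a 6.7-fold lower number from compound 1 to compound 2 (0.83 log units; beyond the scatter), with dimethylamino in place of hydrogen on an aromatic carbon. A partial return toward compound 1 is expected once dimethylamino leaves. Going by the values given here, no compound with methoxy at this place has been measured, so the data do not show how much of that step would remain. The expected move is a 2.6-fold higher number from compound 2 to compound 3 (0.41 log units; beyond the scatter), a modest shift to a higher number in this assay. Compound 3 is estimated at 1800 nM, with an expected range from 650 nM to 5000 nM.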

Compound 3, half-maximal inhibitory concentration: 1410 nM
Beside the measured number, compound 3's estimate is 1.3-fold (0.11 log units) above it; measured number inside the range.
By their numbers in this assay, from the lowest: compounds 2 and 3 (each within the scatter of the next); then compound 1.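

In this assay, among the compounds shown here, the change from hydrogen to methoxy on the aromatic carbon para to a large group gives a 3.4-fold lower number from compound 1 to compound 3 (0.53 log units; beyond the scatter), so dimethylamino is no longer the only group at this place that stands apart from hydrogen. Exchanging dimethylamino for methoxy gives a 2.0-fold higher number from compound 2 to compound 3 (0.30 log units; within the scatter), so these two groups cannot be told apart here. Nothing at hand accounts for the difference of either group from hydrogen.

As far as these compounds go, what remains open is how the number would respond to other groups at this place, such as a primary amine, a hydroxyl, a carboxylic acid or a longer chain like ethoxy. Also open, from the compounds shown here alone, is whether methoxy and dimethylamino would remain indistinguishable on another cell line.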